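The source may hold more compounds than are shown below. What is called first, only, known or untested is meant among the compounds shown, and "the series" means these compounds.

Among the compounds with values here, compound 1 `CCN(Cc1ccc(C)s1)C(=O)COc1ccc(C)cc1` is one of three compounds measured in an assay on HEK293 cells for agonist activity at transient receptor potential cation channel subfamily M member 8 (Homo sapiens), read by fluorescence and calcium flux, with a stated time of 15 min (a lower number here means that less compound is needed, a higher number that more compound is needed for the effect), where compound 1 gives 178 nM. That places it second highest of the three numbers. Compound 2 `Cc1ccc(OCC(=O)N(Cc2cccs2)c2ncccn2)cc1` gives 3700 nM in this assay, a higher number than compound 1 by more than the usual scatter, while compound 3 `CCN(Cc1cccs1)C(=O)COc1ccc(C)cc1O` gives 8 nM in this assay, a lower number than compound 1 by more than the usual scatter. No single-point comparison links any two of these measured compounds, so their values can only be read side by side, not as steps.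

Compound 4 `CCN(Cc1cc[nH]c1)C(=O)COc1ccc(C)cc1` has not yet been measured. It differs from compound 1 in one place: 1H-pyrrol-3-yl in place of 5-methylthiophen-2-yl on a saturated chain carbon bound to an amide-type nitrogen. The thiophene with its methyl is exchanged for a pyrrole, on a saturated chain carbon bound to an amide-type nitrogen. Within the data shown here, with no measured step to anchor this change, the expectation for compound 4 is a modest move toward a higher number, beyond the usual scatter: the estimated step of a 4.5-fold higher number from compound 1 to compound 4 (0.65 log units; beyond the scatter) is expected to raise the value. Compound 4 is therefore estimated at 800 nM in this assay, with a range from 200 nM to 4000 nM.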

Compound 4, half-maximal effective concentration: 21800 nM
For compound 4 the middle estimate is 27-fold (1.44 log units) below the measured one; the measured number lies above the stated range.
By their numbers in this assay, from the lowest: compound 3; then compound 1; then compound 2; then compound 4.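

In this assay, within the data shown here, exchanging the 5-methylthiophen-2-yl group for a 1H-pyrrol-3-yl group gives a 120-fold higher number from compound 1 to compound 4 (2.09 log units; beyond the scatter), the first step in this set that can be read as a change in one place. The step is large, so this position clearly does not treat all five-membered aromatic rings with one hetero atom alike. The exchange swaps sulfur for nitrogen, removes the methyl, moves the point of attachment on the ring and brings in a hydrogen-bond donor, and no measurement shown here explains the size of the step.

Which of these differences carries the step remains open, as they all change together. As far as these compounds go, how a phenyl or furan ring would read at this place is also open.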